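Sulfonamide series on a benzoxazole core: cytotoxicity in HEK293 cells

This account rests on a few compounds, and the source may have more. Where it says the series, first, only, none or still open, it means among the compounds named here.

Three sulfonamides built on a shared core were tested in an ADME assay on HEK293 cells (Homo sapiens) for cytotoxicity, read by resazurin assay, with a stated time of 48 h; a lower number here means that less compound is tolerated, a higher number that more compound is tolerated. For the measured compounds named here, compound 1 `Cc1ccccc1S(=O)(=O)Nc1ccc2oc(-c3ccccc3)nc2c1` gives 57000 nM in this assay and is the only compound of the three with a measured number. Compound 2 `O=S(=O)(Nc1ccc(-c2nc3ccccc3o2)cc1)c1ccccc1C(F)(F)F` reaches only a limit of this assay, > 100000 nM. Compound 3 `C=Cc1ccc(S(=O)(=O)Nc2ccc(-c3nc4ccccc4o3)cc2)cc1` likewise stops at a limit, > 100000 nM. So compound 1 stands alone below (the limit of > 100000 nM in this assay, at which 2 of the 3 values shown sit), while the other two sit at that limit.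

Compound 4 `CS(=O)(=O)Nc1ccc2oc(-c3ccccc3)nc2c1` has not yet been measured in this assay. It differs from compound 1 in one place: methyl in place of 2-methylphenyl on a sulfonyl sulfur. Going by the values given here, no step between two measured compounds is known, so the expectation rests on the spread of the three values alone, two of which lie at the limit. The step from compound 1 to compound 4 is expected to move toward more compound tolerated, estimated as a 1.8-fold higher number from compound 1 to compound 4 (0.24 log units; within the scatter), a step beyond the usual scatter. For compound 4 the estimated value in this assay is 100000 nM, within a range from 40000 nM to 300000 nM, and it may well be reported only as a limit.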

Compound 4, half-maximal cytotoxic concentration: > 100000 nM
Compound 4 gave a limit, no number; the forecaster's own chance of this, stated with the estimate: 55%; the middle value lies on the limit itself.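

For the compounds shown here, this is the first step at this position, the sulfonyl sulfur of the shared core, and the first single change that can be read in this assay: an at least 1.7-fold higher number from compound 1 to compound 4 (0.24 log units; that floor lies within the scatter). Replacing 2-methylphenyl with methyl removes the six-membered aromatic ring from this position without bringing the number down, but the step is only a floor, and that floor does not go beyond the usual scatter. Compound 4 gives a limit and not a number, and it joins the compounds that sit there: the limit of > 100000 nM in this assay, at which 3 of the 4 values shown sit.

Going by these compounds, the true size of the step stays unknown, since the value of compound 4 could lie anywhere past that limit. On these data alone, it also remains open whether an unsubstituted phenyl, a longer chain such as butyl, or an amine on the sulfonyl sulfur would give a measured number in this assay.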